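Replacing the Propargyloxy Group with Dimethylamino

The source may report more compounds than this note shows. Statements on the series, on what has been measured and on what is new or still open speak of the compounds shown alone.

Compound 3 `C#CCOCC(N)C(=O)NCc1ccccc1` carries a propargyloxy group on the shared core of this series. In a functional assay on the whole organism (strain NMRI) for inhibition, with Mus musculus as the target, in the formalin test, with a stated time of 30 min (a lower number here means that less compound is needed, a higher number that more compound is needed for the effect), compound 3 gives 74 mg/kg. Compound 1 `C=CCOCC(N)C(=O)NCc1ccccc1` carries an allyloxy group on the same core, and in this assay compound 1 gives 75 mg/kg. Among the compounds with values here, the one step measured so far, a 1.0-fold lower number from compound 1 to compound 3 (0.01 log units; within the scatter), shows that the two ethers cannot be told apart. Compound 3 and compound 1 thus stand together; their two numbers differ only within the scatter, so no order between them can be claimed. Compound 2 `NCC(N)C(=O)NCc1ccccc1` carries an aminomethyl group on the same core; in this assay compound 2 gives "not determined" (no result reported), so it offers no number.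

Compound 4 `CN(C)CC(N)C(=O)NCc1ccccc1` differs from compound 3 by dimethylamino in place of propargyloxy on a saturated chain carbon, two bonds along the chain from an amine nitrogen and a carbonyl carbon. Within the data shown here, no measured step covers an exchange of the ether oxygen for a nitrogen: the only step in hand, the vinyl-to-ethynyl exchange, lies within the scatter and does not reach this change. Compound 2, the closest structural relative of compound 4, has no result. On this basis compound 4 is expected to show a step of a 1.0-fold higher number from compound 3 to compound 4 (0.01 log units; within the scatter), that is, no change beyond the scatter, with wide uncertainty. The estimate for compound 4 is 75 mg/kg, with a range from 35 mg/kg to 160 mg/kg.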

Compound 4, dose for half-maximal effect: 83 mg/kg
For compound 4 the middle estimate is 1.1-fold (0.04 log units) below the measured one; low and high end bracket the measured number.
By their numbers in this assay, from the lowest: compounds 3, 1 and 4 (each within the scatter of the next).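

In this assay, dimethylamino in place of propargyloxy gives a 1.1-fold higher number from compound 3 to compound 4 (0.05 log units; within the scatter), and dimethylamino in place of allyloxy gives a 1.1-fold higher number from compound 1 to compound 4 (0.04 log units; within the scatter). The earlier compounds had shown only that two ethers could not be told apart; these steps extend that finding beyond the ethers, since neither the exchange of the ether for an amine nor the loss of the triple bond moves the number beyond the scatter, so that compounds 1, 3 and 4 stand together at this saturated chain carbon. No evidence is available that would explain this result.

Any step to compound 2 cannot be read, so the compounds shown do not say how the aminomethyl group, with its unsubstituted amine, compares with the dimethylamino group of compound 4. Also open, on these data alone, is whether the same agreement would hold for a carboxylic acid, a longer chain such as butoxy, or a cyclic amine such as morpholine at this place, since the three numbers cover only the allyloxy, propargyloxy and dimethylamino groups.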